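The source may hold more compounds than are shown below. What is called first, only, known or untested is meant among the compounds shown, and "the series" means these compounds.

Compound 1 `COc1cccc2c1nc(-c1c(F)cccc1F)n2Cc1c(F)cccc1F` stands second highest of the three numbers in a toxicity assay on CCRF-CEM cells (Homo sapiens) for cytotoxicity (a higher number here means that more compound is tolerated, a lower number that less compound is tolerated), where compound 1 gives 44.3 uM; compound 2 `CCc1cccc2c1nc(-c1c(F)cccc1F)n2Cc1c(F)cccc1F` gives 26.1 uM and compound 3 `CN(C)C(=O)c1cccc2c1nc(-c1c(F)cccc1F)n2Cc1c(F)cccc1F` gives 80.1 uM, both within the scatter of compound 1. Compound 4 `Fc1cccc(F)c1Cn1c(-c2c(F)cccc2F)nc2c(CCl)cccc21` is not yet measured and differs from compound 1 in one place: chloromethyl in place of methoxy on an aromatic carbon. Within the data shown here, the steps that bear on a change at this position are a 1.7-fold lower number from compound 1 to compound 2 (0.23 log units; within the scatter) and a 1.8-fold higher number from compound 1 to compound 3 (0.26 log units; within the scatter), while a 3.1-fold higher number from compound 2 to compound 3 (0.49 log units; beyond the scatter). Neither measured step involves chloromethyl, so the step cannot be anchored closely; an expected step of a 2.0-fold lower number from compound 1 to compound 4 (0.30 log units; within the scatter), downward but small, is taken as the working guess. The estimate for compound 4 in this assay is 22 uM, with a range from 6 uM to 65 uM.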

Compound 4, half-maximal toxic concentration: 13.4 uM
Beside the measured number, compound 4's estimate is 1.6-fold (0.22 log units) above it, and the stated range covers the measured number.
By their numbers in this assay, from the lowest: compounds 4, 2, 1 and 3 (each within the scatter of the next, the first and the last beyond it).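

In this assay chloromethyl gives the first step away from methoxy on this aromatic carbon that lies beyond the scatter (a 3.3-fold lower number from compound 1 to compound 4 (0.52 log units; beyond the scatter)), and the gap to dimethylcarbamoyl is larger still (a 6.0-fold lower number from compound 3 to compound 4 (0.78 log units; beyond the scatter)). Chloro in place of methyl on the saturated chain carbon stays within the scatter (a 1.9-fold lower number from compound 2 to compound 4 (0.29 log units; within the scatter)), so chloromethyl and ethyl are not separated here. No evidence is available that bears on these steps.

On these data alone, it remains open how an aminomethyl or hydroxymethyl group would stand at this position. A longer chain carrying chlorine is also untested by the compounds shown.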